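The source may report more compounds than this note shows. Statements on the series, on what has been measured and on what is new or still open speak of the compounds shown alone.

Measured so far in a functional assay on MGC-803 cells (Homo sapiens) for antiproliferative activity, read by MTT assay, with a stated time of 48 h; on this read-out higher numbers stand for weaker inhibition and lower numbers for stronger inhibition:
- compound 1 `CCCCCCCCCCCCn1cc(COC[C@@H]2OC[C@H](N)[C@@H]2O)nn1`: 21400 nM
- compound 2 `CCCCCCCCCCCCCCCCCCn1cc(COC[C@@H]2OC[C@H](N)[C@@H]2O)nn1`: 15400 nM
- compound 3 `CCCCCCCn1cc(COC[C@@H]2OC[C@H](N)[C@H]2O)nn1`: > 128000 nM (a limit)

Compound 3 has no number on this scale, only a limit. Compound 4 `CCCCCCCCCCCCCCCCn1cc(COC[C@@H]2OC[C@H](N)[C@H]2O)nn1` departs from it by one change: nonyl in place of hydrogen on a saturated chain carbon, seven bonds along the chain from an aromatic nitrogen. Put another way, the same difference reads methyl to decyl.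

Among the compounds with values here, only one measured step bears on this change. It is a 1.4-fold lower number from compound 1 to compound 2 (0.14 log units; within the scatter), which extends a chain that is already long, at a place further out, and it gives no clear movement. The core of compound 1 is also not identical to that of compound 3, so this guidance is loose.

After the change, compound 4 carries a long chain, as do compound 1 at 21400 nM and compound 2 at 15400 nM. A clear move towards stronger inhibition is therefore expected in this assay. The expected size of the move is an at least 5.1-fold lower number from compound 3 to compound 4 (0.70 log units; beyond the scatter). Compound 4 is estimated at 25000 nM, with an expected range from 10000 nM to 80000 nM.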

Compound 4, half-maximal inhibitory concentration: 5340 nM
Beside the measured number, compound 4's estimate is 4.7-fold (0.67 log units) above it; the measured number lies below the stated range.
By their numbers in this assay, from the lowest: compound 4; then compounds 2 and 1 (each within the scatter of the next). At a limit, above all of these: compound 3.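

In this assay, nonyl in place of hydrogen on a saturated chain carbon, seven bonds along the chain from an aromatic nitrogen, gives an at least 23-fold lower number from compound 3 to compound 4 (1.37 log units; beyond the scatter). This is the first chain change shown to move the number beyond the scatter, whereas the only earlier step, on the core of compound 1, is a 1.4-fold lower number from compound 1 to compound 2 (0.14 log units; within the scatter). Compound 3 has only a limit, so the step gives a lower bound on the size of the move: the limit of > 128000 nM in this assay, at which 1 of the 4 values shown sits.

On these data alone, whether a longer chain on the core of compound 4 would lower the number further stays open, as does whether a chain carrying an amine or a carboxylic acid would keep the step. Compound 1 and compound 4 differ in both core and chain, so the effect of the core alone cannot be read here.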